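The compounds below may be only part of what the source reports. "The series", "measured", "known", "first", "only" and "open" are said of these compounds alone.

The measured compounds:
Compound 1 `O=C(NCCCCc1cccs1)n1c(=O)oc2ccccc21` gives 37 nM in an assay on HEK293 cells for inhibition of acid ceramidase (Homo sapiens), with a stated time of 10 min; a lower number here means a stronger inhibitor, a higher number a weaker inhibitor.
Compound 2 `O=C(NCCOCc1ccccc1)n1c(=O)oc2ccccc21` gives 649 nM in this assay.
Compound 3 `O=C(NCCCCc1ccccc1)n1c(=O)oc2ccc(-c3ccc(F)cc3)cc21` gives 56 nM in this assay.

Compound 1 carries the lowest of the three numbers. Compound 3 sits close to it, within the usual scatter of repeated measurements, while compound 2 stands clearly apart, beyond that scatter. The account now turns to compound 4 `O=C(NCCCCCc1ccccc1)n1c(=O)oc2ccccc21`, which has not been measured and differs from compound 1 in a single place: benzyl in place of thiophen-2-yl on a saturated chain carbon, four bonds along the chain from an amide-type nitrogen. Going by the values given here, no measured pair shows this same change, so no step size can be read off directly. In this assay the step is expected to be small, in no direction beyond the scatter. The step of a 1.4-fold higher number from compound 1 to compound 4 (0.13 log units; within the scatter) is thus expected to be modest. Compound 4 is estimated at 50 nM, with a range from 15 nM to 200 nM.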

Compound 4, half-maximal inhibitory concentration: 54 nM
Compound 4: the middle estimate sits 1.1-fold (0.03 log units) below what was measured; the measured number falls inside the stated range.
By their numbers in this assay, from the lowest: compounds 1, 4 and 3 (each within the scatter of the next); then compound 2.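

In this assay, going by these compounds alone, the step of a 1.5-fold higher number from compound 1 to compound 4 (0.16 log units; within the scatter) is the first one read at this position, and it shows that benzyl in place of thiophen-2-yl on a saturated chain carbon leaves the number within the scatter. In this pair, a six-membered aromatic ring of carbon only thus serves as well as a five-membered aromatic ring with a sulfur atom. Nothing at hand explains this result. The compounds shown leave open how a pyridin-2-yl group, an amine or a carboxylic acid would read at this place.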